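The compounds below may be only part of what the source reports. "The series", "measured", "known", "first", "only" and "open" are said of these compounds alone.

Measured compounds in the series:

- compound 1, `CC(C(=O)NCc1ccc(C(F)(F)F)cc1N1CCCC1)c1ccc(NS(C)(=O)=O)c(F)c1`, gives 2.3 nM in an assay on CHO cells for antagonist activity at transient receptor potential cation channel subfamily V member 1 (Homo sapiens), read by FLIPR; a higher number here means a weaker inhibitor, a lower number a stronger inhibitor
- compound 2, `CC1CCN(c2cc(C(F)(F)F)ccc2CNC(=O)C(C)c2ccc(NS(C)(=O)=O)c(F)c2)CC1`, gives 0.9 nM in this assay
- compound 3, `CC(C(=O)NCc1ccc(C(F)(F)F)cc1SC1CCCCC1)c1ccc(NS(C)(=O)=O)c(F)c1`, gives 0.5 nM in this assay

Compound 2 holds the second highest of the three numbers; its nearest neighbour is compound 3, a step within the scatter (a 1.8-fold lower number from compound 2 to compound 3 (0.26 log units; within the scatter)), while its step to compound 1 is beyond it (a 2.6-fold lower number from compound 1 to compound 2 (0.41 log units; beyond the scatter)).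

Compound 4, `CC(C(=O)NCc1ccc(C(F)(F)F)cc1Cl)c1ccc(NS(C)(=O)=O)c(F)c1`, is not yet measured. Its change from compound 2: chloro in place of 4-methylpiperidin-1-yl on an aromatic carbon.

Going by the values given here, two measured steps bear on this position on the aromatic ring: a 2.6-fold lower number from compound 1 to compound 2 (0.41 log units; beyond the scatter) and a 4.6-fold lower number from compound 1 to compound 3 (0.66 log units; beyond the scatter), both modest and both in the direction of lower numbers when the pyrrolidin-1-yl of compound 1 is exchanged for the larger groups of compound 2 and compound 3. Compound 4 moves to a single chlorine at the same place, the opposite sense of that exchange. A step to a higher number than compound 2, beyond the scatter, is therefore expected for compound 4 in this assay, of roughly a 5.6-fold higher number from compound 2 to compound 4 (0.74 log units; beyond the scatter). The estimate for compound 4 is 5 nM, with a range from 1.5 nM to 20 nM.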

Compound 4, inhibition constant: 4 nM
Compound 4: middle estimate off by 1.3-fold (0.10 log units), on the high side; the measured number falls inside the stated range.
By their numbers in this assay, from the lowest: compounds 3 and 2 (each within the scatter of the next); then compounds 1 and 4 (each within the scatter of the next).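

In this assay, chloro at this place gives up the gain seen with the two larger groups: a 4.4-fold higher number from compound 2 to compound 4 (0.65 log units; beyond the scatter) and an 8.0-fold higher number from compound 3 to compound 4 (0.90 log units; beyond the scatter) are both beyond the scatter, and the second is the widest step in the set. Against pyrrolidin-1-yl, the exchange gives a 1.7-fold higher number from compound 1 to compound 4 (0.24 log units; within the scatter), within the scatter, so a lone chloro with no ring cannot be told apart from that five-membered amine, and a ring at this place is not enough by itself to lower the number. Nothing at hand explains these steps.

Open, from the compounds shown here alone, is whether an open-chain amine such as dimethylamino, or a small group such as methoxy, would fall with chloro or with compound 3. Also open, going by these compounds, is what the sulfur of compound 3 contributes, which a cyclohexyloxy or cyclohexylamino group would test.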